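Swapping the Methoxyphenyl Group: Clearance of Compound 4

A few compounds are considered here, and "the series" means these few. Any claim that something is new, unique, unknown or untested is made for them only; others in the source may bear on it.

- Compound 1 `COc1ccc(C(=O)N2CCC(=CC(=O)N[C@@H]3CCN(Cc4ccc5cc(F)ccc5c4)C3)CC2)cc1`: 252 mL/min/kg
- Compound 2 `COc1cccc(C(=O)N2CCC(=CC(=O)N[C@@H]3CCN(Cc4ccc5cc(F)ccc5c4)C3)CC2)c1`: 500 mL/min/kg
- Compound 3 `COc1cccc(O)c1C(=O)N1CCC(=CC(=O)N[C@@H]2CCN(Cc3ccc4cc(F)ccc4c3)C2)CC1`: 192 mL/min/kg

In an in vitro ADME assay on microsomes from liver (Homo sapiens) for metabolic stability (on this read-out lower numbers stand for slow clearance and higher numbers for fast clearance), compound 1 gives the second highest of these three numbers, yet neither step from it reaches beyond the scatter. Compound 4 `COc1ccc(O)c(C(=O)N2CCC(=CC(=O)N[C@@H]3CCN(Cc4ccc5cc(F)ccc5c4)C3)CC2)c1` has not been measured. It keeps the core of compound 1 and changes only the group on a carbonyl carbon: 2-hydroxy-5-methoxyphenyl in place of 4-methoxyphenyl on a carbonyl carbon.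

The nearest guide is compound 3 at 192 mL/min/kg, whose 2-hydroxy-6-methoxyphenyl group also holds a hydroxy. Among the measured compounds shown here, two measured steps bear on the change: a 1.3-fold lower number from compound 1 to compound 3 (0.12 log units; within the scatter) and a 2.6-fold lower number from compound 2 to compound 3 (0.42 log units; beyond the scatter). Only the second lies beyond the scatter, and neither matches the new group exactly. Three compounds are thin evidence, so in this assay no change beyond the scatter is expected, with at most a slight lean towards a lower number. The expected step is a 1.1-fold lower number from compound 1 to compound 4 (0.04 log units; within the scatter). Compound 4 is estimated at 230 mL/min/kg, with an expected range of 120 mL/min/kg to 450 mL/min/kg.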

Compound 4, clearance: 119 mL/min/kg
The estimate for compound 4 lay 1.9-fold (0.29 log units) above the measured number; the whole stated range lies above it.
By their numbers in this assay, from the lowest: compounds 4, 3, 1 and 2 (each within the scatter of the next, the first and the last beyond it).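

In this assay the 2-hydroxy-5-methoxyphenyl group gives the first step from compound 1 that lies beyond the scatter: a 2.1-fold lower number from compound 1 to compound 4 (0.33 log units; beyond the scatter). The two hydroxy-bearing groups cannot be separated, with a 1.6-fold lower number from compound 3 to compound 4 (0.21 log units; within the scatter) inside the scatter, yet only compound 4 clears that scatter against compound 1, so compound 3 goes against any simple rule that a hydroxy alone does this. Adding hydroxy in place of hydrogen on an aromatic carbon of the 3-methoxyphenyl group produces the largest step here, a 4.2-fold lower number from compound 2 to compound 4 (0.62 log units; beyond the scatter).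

No measurement shown explains why these numbers move. As far as these compounds go, whether an amine or a fluorine in place of the hydroxy would give a similar clearance remains open, as these compounds all carry a hydroxy or a hydrogen there.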